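The source may hold more compounds than are shown below. What is called first, only, known or untested is meant among the compounds shown, and "the series" means these compounds.

Measured in a functional assay on HeLa cells (Homo sapiens) for inhibition, read by MTT assay, with a stated time of 72 h; a higher number here means a weaker inhibitor, a lower number a stronger inhibitor:
- compound 1 `Nc1ncnc2c1c(-c1cnc3[nH]ccc3c1)nn2CCCCC(=O)NO`: > 150000 nM (a limit)
- compound 2 `Nc1ncnc2c1c(-c1cnc3[nH]ccc3c1)nn2CCCCCCCCCC(=O)NO`: 7560 nM
- compound 3 `Nc1nc2cc(-c3nn(CCC(=O)NO)c4ncnc(N)c34)ccc2o1`: > 150000 nM (a limit)

Compound 3 gives > 150000 nM, which is a limit and not a number. Compound 4 `Nc1nc2cc(-c3nn(CCCCCCC(=O)NO)c4ncnc(N)c34)ccc2o1` differs from it as follows: 4-(hydroxycarbamoyl)butyl in place of hydroxycarbamoyl on a saturated chain carbon, two bonds along the chain from an aromatic nitrogen. In words, this is 4-(hydroxycarbamoyl)butyl in place of hydroxycarbamoyl on a saturated chain carbon, two bonds along the chain from an aromatic nitrogen.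

Among the measured compounds shown here, the one measured step that bears on this also lengthens the chain: an at least 19-fold lower number from compound 1 to compound 2 (1.29 log units; beyond the scatter), a large step beyond the scatter. The core of compound 3 differs from that of compound 1, so this guide is only approximate. A large move towards a lower number is still expected in this assay, namely an at least 5.0-fold lower number from compound 3 to compound 4 (0.69 log units; beyond the scatter). For compound 4, the estimated value is 30000 nM. The expected range for compound 4 runs from 6000 nM to 150000 nM.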

Compound 4, half-maximal inhibitory concentration: 6410 nM
Estimate against measurement, compound 4: 4.7-fold (0.67 log units) above, within the range that was stated.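

Lengthening the chain that carries the hydroxycarbamoyl group lowers the number on the core of compound 3 as well, not only on the core of compound 1: in this assay, the change gives an at least 23-fold lower number from compound 3 to compound 4 (1.36 log units; beyond the scatter). Compound 3 has a limit and not a number, so this step gives only a minimum size: the limit of > 150000 nM in this assay, at which 2 of the 4 values shown sit.

On these data alone, how the number changes at chain lengths between those of compound 3 and compound 4, or with a still longer chain, stays open. So does whether a carboxylic acid or an amine at the chain end would give a similar result.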